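Isobutyl for vinyl on a benzylated sugar-like core

The source may hold more compounds than are shown below. What is called first, only, known or untested is meant among the compounds shown, and "the series" means these compounds.

Measured compounds:
compound 1 `C=C[C@@H]1O[C@H](COCc2ccccc2)[C@@H](OCc2ccccc2)[C@H](OCc2ccccc2)[C@H]1O`: 11800 nM
compound 2 `O[C@@H]1[C@@H](O)[C@H](Cc2ccccc2)O[C@H](COCc2ccccc2)[C@H]1O`: "not active" (no number reported)
compound 3 `C=C[C@H]1O[C@H](COCc2ccccc2)[C@@H](OCc2ccccc2)[C@H](OCc2ccccc2)[C@H]1O`: "not active" (no number reported)

Among the measured compounds shown here, in a functional assay on HL-60 cells (Homo sapiens) for antiproliferative activity, read by MTT assay (a higher number here means a weaker inhibitor, a lower number a stronger inhibitor), compound 1 gives 11800 nM, the only number in the set; compound 2 and compound 3 are recorded without a number, compound 2 as "not active" (no number reported) and compound 3 as "not active" (no number reported). What separates compound 1 from compound 3 is the fact that compounds 1 and 3 differ only in the configuration as drawn, and the two values show that only compound 1 yields a measurable result.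

Compound 4 `CC(C)C[C@@H]1O[C@H](COCc2ccccc2)[C@@H](OCc2ccccc2)[C@H](OCc2ccccc2)[C@H]1O` keeps the core of compound 1 and changes one group: isobutyl in place of vinyl on a saturated ring carbon

For the measured compounds named here, no step between two measured compounds is available, so the size of this change can only be expected. An expectation of a modest step is reasonable, not clearly beyond the scatter, in either direction. For compound 4 the expected value in this assay is 8000 nM, with a range from 2500 nM to 30000 nM. This estimate means a step of a 1.5-fold lower number from compound 1 to compound 4 (0.17 log units; within the scatter) expected to stay close to the scatter.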

Compound 4, half-maximal inhibitory concentration: 8500 nM
Beside the measured number, compound 4's estimate is 1.1-fold (0.03 log units) below it, within the range that was stated.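

In this assay, replacing vinyl with isobutyl on this saturated ring carbon next to the ring oxygen gives a 1.4-fold lower number from compound 1 to compound 4 (0.14 log units; within the scatter), so the two groups cannot be told apart at this position. Among the compounds shown here, until now, compound 1 was the only compound with a number; compound 4 gives 8500 nM, which shows that a measurable result at this position does not depend on the double bond of the vinyl group. Nothing available explains why the two groups read alike in this assay.

As far as these compounds go, it remains open whether an amine, a carboxylic acid or a longer chain at this ring carbon would move the value beyond the scatter. Also open, from the compounds shown here alone, is whether isobutyl in the configuration drawn for compound 3 would give a number at all.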